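The source may hold more compounds than are shown below. What is called first, only, known or untested is meant among the compounds shown, and "the series" means these compounds.

Of the compounds shown here, three have so far been tested in a functional assay on HT-29 cells (Homo sapiens) for inhibition, read by MTT assay, with a stated time of 72 h; a lower number here means a stronger inhibitor of growth, a higher number a weaker inhibitor of growth. Compound 1, `N#C/C(=C\c1c(F)c(F)c(F)c(F)c1F)C(=O)c1c[nH]c2ccccc12`, gives 18000 nM in this assay. Compound 2, `N#C/C(=C\c1ccc[nH]1)C(=O)NCc1ccc(Cl)c(Cl)c1`, gives 85000 nM. Compound 3, `COc1ccc(CNC(=O)/C(C#N)=C/c2ccco2)cc1`, gives 22000 nM. Among these three numbers compound 3 stands second highest. The number of compound 1 lies within the usual scatter of that of compound 3, so the two cannot be told apart, while the number of compound 2 is the higher one and lies beyond the scatter.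

Compound 4, `COc1ccc(CNC(=O)/C(C#N)=C/c2ccc(Cl)o2)cc1`, has not yet been measured. It differs from compound 3 in one place: chloro in place of hydrogen on an aromatic carbon, on an aromatic carbon of a five-membered aromatic ring with one oxygen, next to the ring oxygen. Cut one bond further out, the change reads furan-2-yl to 5-chlorofuran-2-yl.

Among the measured compounds shown here, no two measured compounds differ in a single place, so there is no step to lean on for this change. For a change of one atom on the ring, the step from compound 3 to compound 4 is expected to be modest, a 1.5-fold lower number from compound 3 to compound 4 (0.17 log units; within the scatter), toward a somewhat lower number but hardly beyond the scatter. Compound 4 is therefore expected to give about 15000 nM in this assay, with a range from 5000 nM to 45000 nM.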

Compound 4, concentration for 50% growth inhibition: 9000 nM
Compound 4: the middle estimate sits 1.7-fold (0.22 log units) above what was measured, within the range that was stated.
By their numbers in this assay, from the lowest: compounds 4, 1 and 3 (each within the scatter of the next, the first and the last beyond it); then compound 2.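

In this assay, chloro in place of hydrogen on an aromatic carbon, next to the ring oxygen of the five-membered aromatic ring, gives a 2.4-fold lower number from compound 3 to compound 4 (0.39 log units; beyond the scatter), and this step lies beyond the usual scatter. This is the first change in a single place among the compounds shown, and it establishes that growth inhibition in this assay responds to what sits at this ring position, even when the change adds only 1 heavy atom. No measurement at hand explains why the number falls, so the step stands as an observation without a known cause.

Only hydrogen and chloro have been seen at this position, so the compounds shown leave open whether a methyl group, a bromo group or an amine there would lower the number further, leave it unchanged or raise it. They also leave open whether chloro would have a similar effect on another core, such as that of compound 2, or whether the step holds only alongside the rest of compound 3.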